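Swapping an aromatic ether for phenethyl: a permeability outlook

The compounds below may be only part of what the source reports. "The series", "measured", "known", "first", "only" and "open" are said of these compounds alone.

Measured compounds:
compound 1 `c1ccc(CCc2ccc3c(NCCCNCc4ccco4)ccnc3c2)cc1` gives 23 10^-6 cm/s
compound 2 `COc1ccccc1Oc1ccc2c(NCCCNCc3ccco3)ccnc2c1` gives 317 10^-6 cm/s
compound 3 `COc1ccc(F)cc1CNCCCNc1ccnc2cc(Oc3ccccc3OC)ccc12` gives 317 10^-6 cm/s

The three compounds were tested in an ADME assay for permeability, using PAMPA, with a stated time of 30 min, at pH 7.4; a lower number here means that the compound crosses the layer more slowly, a higher number that the compound crosses the layer faster. Compound 2 and compound 3 share the core carrying the 2-methoxyphenoxy group and differ only at the amine end, where (5-fluoro-2-methoxyphenyl in place of furan-2-yl on a saturated chain carbon bound to an amine nitrogen); this change gave no change at the digits printed from compound 2 to compound 3 (within the scatter). Compound 1 carries phenethyl instead, and the step of a 14-fold lower number from compound 2 to compound 1 (1.14 log units; beyond the scatter) shows how much that exchange mattered on the furan-bearing side chain: the change was phenethyl in place of 2-methoxyphenoxy on an aromatic carbon.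

Compound 4 `COc1ccc(F)cc1CNCCCNc1ccnc2cc(CCc3ccccc3)ccc12` has not yet been measured. It differs from compound 3 in that (phenethyl in place of 2-methoxyphenoxy on an aromatic carbon). This is the same change as that from compound 2 to compound 1, at the same place on the same kind of ring, and only the amine end differs between the two cores. Since that earlier step was large, a step of similar size from compound 3 is expected; the estimate for compound 3 to compound 4 is a 13-fold lower number from compound 3 to compound 4 (1.10 log units; beyond the scatter), because compound 2 to compound 1 gave a 14-fold lower number from compound 2 to compound 1 (1.14 log units; beyond the scatter). On that basis compound 4 is expected to give about 25 10^-6 cm/s in this assay. Within the data shown here, the expected range for compound 4 runs from 10 10^-6 cm/s to 70 10^-6 cm/s, reflecting that only one prior example of this change is available.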

Compound 4, apparent permeability: 23 10^-6 cm/s
Beside the measured number, compound 4's estimate is 1.1-fold (0.04 log units) above it; low and high end bracket the measured number.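

In this assay, among these compounds, placing phenethyl where 2-methoxyphenoxy stood, now with the 5-fluoro-2-methoxyphenyl group at the amine end, gave a 14-fold lower number from compound 3 to compound 4 (1.14 log units; beyond the scatter), and this step matches the one seen with furan-2-yl at that end: the same change on two cores in this assay, a 14-fold lower number (1.14 log units; beyond the scatter) from compound 2 to compound 1 and a 14-fold lower number (1.14 log units; beyond the scatter) from compound 3 to compound 4, 1.0-fold (0.00 log units) apart, within the scatter of two such steps The exchange at the amine end also carried over, since it gave no change at the digits printed from compound 1 to compound 4 (within the scatter) with phenethyl on the core, as it had with 2-methoxyphenoxy: the same change on two cores in this assay, no change at the digits printed (within the scatter) from compound 2 to compound 3 and no change at the digits printed (within the scatter) from compound 1 to compound 4, 1.0-fold (0.00 log units) apart, within the scatter of two such steps The four compounds thus show that, in this assay, each change kept its size when moved from one of these cores to the other, but they rest on only two amine-end groups and two groups on the aromatic carbon, so they do not show that the phenethyl step would hold for other amine-end groups, nor do they say what produces it.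

The compounds shown leave open which part of the 2-methoxyphenoxy group matters, as a plain phenoxy or benzyl group on the same aromatic carbon would separate the ether oxygen and the methoxy from the rest of the group. They also leave open whether the same step would appear with a saturated amine such as morpholine, or a carboxylic acid, at the amine end.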